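Ester in place of ether on the aryl tail

A few compounds are considered here, and "the series" means these few. Any claim that something is new, unique, unknown or untested is made for them only; others in the source may bear on it.

Measured so far in an assay on HEK293 cells for inhibition of N-acylethanolamine-hydrolyzing acid amidase (Rattus norvegicus), read by LC-MS, with a stated time of 30 min; a higher number here means a weaker inhibitor, a lower number a stronger inhibitor:
compound 1 `O=C(CCCCCCc1ccc(Cl)cc1)N1CCCC1` gives 34500 nM
compound 2 `O=C(CCCCCCc1ccc(O)cc1)N1CCCC1` gives 5600 nM
compound 3 `COc1ccc(CCCCCCC(=O)N2CCCC2)cc1` gives 35400 nM

Compound 3 stands at the highest of the three numbers, though its gap to compound 1 is within the scatter; only compound 2 is set apart, as the steps show: a 6.2-fold lower number from compound 1 to compound 2 (0.79 log units; beyond the scatter) and a 6.3-fold higher number from compound 2 to compound 3 (0.80 log units; beyond the scatter), while a 1.0-fold higher number from compound 1 to compound 3 (0.01 log units; within the scatter).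

Compound 4 `COC(=O)c1ccc(CCCCCCC(=O)N2CCCC2)cc1` follows from compound 3 by the change (methoxycarbonyl in place of methoxy on an aromatic carbon). Within the data shown here, none of the measured steps introduces a methoxycarbonyl or any group beyond chloro, hydroxy and methoxy, so none bears directly on this step; the nearest analogy is that exchanging chloro for methoxy left the number unchanged, and only the hydroxy compound 2 departed from the others. A step of no more than the scatter is therefore expected, a 1.2-fold lower number from compound 3 to compound 4 (0.07 log units; within the scatter), with the direction uncertain. For compound 4 the estimate in this assay is 30000 nM, with a range from 8000 nM to 110000 nM.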

Compound 4, half-maximal inhibitory concentration: > 100000 nM
Compound 4 gave a limit, no number (the forecaster's own chance of this, stated with the estimate: 15%); middle value at least 3.3-fold (0.52 log units) away from the limit.
By their numbers in this assay, from the lowest: compound 2; then compounds 1 and 3 (each within the scatter of the next). At a limit, above all of these: compound 4.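

In this assay compound 4 stands at a limit of the assay, not at a number: the limit of > 100000 nM in this assay, at which 1 of the 4 values shown sits.

The exchange of chloro for methoxy left the number within the scatter, but methoxycarbonyl on this aromatic carbon, para to a large group, separates compound 4 from all three earlier compounds, with an at least 2.8-fold higher number from compound 3 to compound 4 (0.45 log units; beyond the scatter), an at least 2.8-fold higher number from compound 1 to compound 4 (0.46 log units; beyond the scatter) and an at least 17-fold higher number from compound 2 to compound 4 (1.25 log units; beyond the scatter). This position therefore now gives three levels rather than two: compound 2 lowest, compounds 1 and 3 together, and compound 4 at the limit.

As far as these compounds go, with only a limit for compound 4, the full size of these steps stays open. Also open, from the compounds shown here alone, is whether an amine or a carboxylic acid at this position would match the low number of compound 2 or follow compound 4, and whether either pattern would hold on a longer chain.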